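Aryl exchange on the saturated ring carbon: lipophilicity notes

The source may hold more compounds than are shown below. What is called first, only, known or untested is meant among the compounds shown, and "the series" means these compounds.

Measured so far:
compound 1 `COc1ccc(C2SCC(=O)N2NC(=O)CNC(=O)c2ccccc2)cc1`: 1.85
compound 2 `O=C(CNC(=O)c1ccccc1)NN1C(=O)CSC1c1c[nH]c2ccccc12`: 1.7

In a physicochemical assay for lipophilicity (on this read-out higher numbers stand for higher lipophilicity and lower numbers for lower lipophilicity), compound 1 gives 1.85 and compound 2 gives 1.7. The number for compound 1 is the higher of the two shown, but a number 0.15 log units lower from compound 1 to compound 2 (within the scatter), so the two stand level. Compound 3 `O=C(CNC(=O)c1ccccc1)NN1C(=O)CSC1c1ccccc1Cl` carries 2-chlorophenyl in place of 4-methoxyphenyl on a saturated ring carbon. Among the measured compounds shown here, no measured step covers this change: the single known step, the indolyl exchange, lies within the scatter and does not bear on a 2-chlorophenyl. On that footing compound 3 is expected to show a number 0.65 log units higher from compound 1 to compound 3 (beyond the scatter). The estimate for compound 3 is 2.5, with a range from 2 to 3.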

Compound 3, partition coefficient: 2.3
Compound 3: the middle estimate sits 0.20 log units above what was measured; the range from low to high includes it.
By their numbers in this assay, from the lowest: compounds 2 and 1 (each within the scatter of the next); then compound 3.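

Among the compounds shown here, with 2-chlorophenyl on the saturated ring carbon, the series shows a number 0.45 log units higher from compound 1 to compound 3 (beyond the scatter) and a number 0.60 log units higher from compound 2 to compound 3 (beyond the scatter) in this assay as the first steps at this position beyond the scatter. The aryl group at this carbon can therefore move the number, which the level pair of compound 1 and compound 2 did not show. Still open, on these data alone, is whether a plain phenyl, or an aryl carrying an amine or a carboxylic acid, would shift the number at this carbon. No evidence is available that bears on this result.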